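Opening a ring into a fluorinated chain at the amine-bound carbon

The source may report more compounds than this note shows. Statements on the series, on what has been measured and on what is new or still open speak of the compounds shown alone.

Measured so far:
- compound 1 `NC[C@H]1CC[C@H](CN(C[C@H]2Cc3ccccc3CN2)[C@H]2CCCc3cccnc32)CC1`: 340 nM
- compound 2 `NCC1CC1CN(C[C@H]1Cc2ccccc2CN1)[C@H]1CCCc2cccnc21`: 6.4 nM; 13 nM (2 entries)
- compound 3 `NCC1=C(CN(C[C@H]2Cc3ccccc3CN2)[C@H]2CCCc3cccnc32)CCCC1`: 230 nM

All three share a core and differ only in the group hung on a saturated chain carbon bound to an amine nitrogen. In a functional assay on CCRF-CEM cells for antagonist activity at C-X-C chemokine receptor type 4 (Homo sapiens), read by calcium flux, with stated times of 25 min and 90 s (on this read-out lower numbers stand for stronger inhibition and higher numbers for weaker inhibition), compound 3 gives the lowest of the two single numbers, with compound 1 nearest; the step of a 1.5-fold lower number from compound 1 to compound 3 (0.17 log units; within the scatter) is within the scatter, so the saturated ring and the ring with one double bond behave alike. Compound 2, with its small ring, sits far lower than both, but the several entries for compound 2 the several entries of compound 2 in this assay, 6.4 nM; 13 nM (2 entries) also show how much one compound can wander on repetition.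

Compound 4 `C/C(CN)=C(\F)CN(C[C@H]1Cc2ccccc2CN1)[C@H]1CCCc2cccnc21` is the next step from compound 3: 2-(aminomethyl)-1-fluoroprop-1-en-1-yl in place of 2-(aminomethyl)cyclohex-1-en-1-yl on a saturated chain carbon bound to an amine nitrogen. The ring is opened into a shorter, fluorine-bearing chain. Going by the values given here, no measured step covers such a ring opening; the only comparable step, that of compound 1 to compound 3, was flat. Compound 2 hints that a smaller group can help, though it differs in another way. A modest improvement is therefore expected, with wide uncertainty: the step of a 2.1-fold lower number from compound 3 to compound 4 (0.32 log units; beyond the scatter) is the estimate. For compound 4 the expected value is 110 nM, within 25 nM to 500 nM.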

Compound 4, half-maximal inhibitory concentration: 28 nM
Estimate against measurement, compound 4: 3.9-fold (0.59 log units) above, and the stated range covers the measured number.
By their numbers in this assay, from the lowest: compound 4; then compounds 3 and 1 (each within the scatter of the next).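

In this assay, this position proves sensitive to the group it carries: opening the ring gives an 8.2-fold lower number from compound 3 to compound 4 (0.91 log units; beyond the scatter), and replacing the saturated ring gives a 12-fold lower number from compound 1 to compound 4 (1.08 log units; beyond the scatter), whereas exchanging one six-membered ring for the other gave only a 1.5-fold lower number from compound 1 to compound 3 (0.17 log units; within the scatter). A six-membered carbon ring is therefore not needed here, since 2-(aminomethyl)-1-fluoroprop-1-en-1-yl has no ring and still inhibits more strongly than either ring-bearing group. Both new steps are also larger than the spread seen when a single compound is repeated: the several entries of compound 2 in this assay, 6.4 nM; 13 nM (2 entries)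

Removing the ring and adding fluorine arrive together in this change, so the compounds shown cannot say which of the two accounts for the gain. The same open chain with hydrogen in place of the fluorine would separate them, and the reason for the gain remains unknown.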